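The source may report more compounds than this note shows. Statements on the series, on what has been measured and on what is new or still open speak of the compounds shown alone.

Compound 1 `CSc1nc2c(C)nsc2[nH]1` gives 13000 nM in a functional assay on L1210 cells (Mus musculus) for antiproliferative activity; on this read-out higher numbers stand for weaker inhibition and lower numbers for stronger inhibition.
Compound 2 `CSc1nc2cnsc2[nH]1` gives 7000 nM in this assay.
Compound 3 `CSc1nc2c(C)nsc2n1[C@@H]1O[C@H](CO)[C@@H](O)[C@@H]1O` reaches only a limit in this assay, > 100000 nM, so no number is known for it.

Between compound 1 and compound 2 the change is hydrogen in place of methyl on an aromatic carbon, and it gave a 1.9-fold lower number from compound 1 to compound 2 (0.27 log units; within the scatter). How the core of compound 1 and the core of compound 3 differ is not broken down here. Compound 4 `CSc1nc2cnsc2n1[C@@H]1O[C@H](CO)[C@@H](O)[C@@H]1O` is not yet measured; it arises from compound 3 by the same change, (hydrogen in place of methyl on an aromatic carbon). Compound 3 sits at the limit of > 100000 nM in this assay, at which 1 of the 3 values shown sits. In this assay the step from compound 3 to compound 4 is expected to be small, a step that the limit leaves unreadable from compound 3 to compound 4, because the same change gave a 1.9-fold lower number from compound 1 to compound 2 (0.27 log units; within the scatter). Compound 4 is therefore expected to give about 150000 nM, within 50000 nM to 500000 nM, most likely again only a limit rather than a number.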

Compound 4, half-maximal inhibitory concentration: > 100000 nM
Compound 4: only a limit was reported (the forecaster's own chance of this, stated with the estimate: 70%); the middle value lies beyond the limit too.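

Compound 3 and compound 4 both reach only a limit in this assay, so no step can be read between them. The compounds shown leave open whether hydrogen in place of methyl changes the activity at all on the core of compound 3.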